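The source may report more compounds than this note shows. Statements on the series, on what has been measured and on what is new or still open speak of the compounds shown alone.

Measured in an assay on isolated protein for activation of cGMP-dependent protein kinase 1 (Homo sapiens), read by ADP-Glo, with stated times of 30 min and 2 h, in the presence of a further agent that is not named here; a higher number here means that more compound is needed for the effect, a lower number that less compound is needed:
compound 1 `Cc1cc(C(=O)O)ccc1C(C)N1CCC[C@H](O[C@H](CO)c2cc(Cl)cc(Cl)c2)[C@@H]1c1ccccc1`, 18000 nM
compound 2 `Cc1cc(C(=O)O)ccc1CN1C(C)CC[C@H](O[C@H](CO)c2cc(Cl)cc(Cl)c2)[C@@H]1c1ccccc1`, 36000 nM
compound 3 `Cc1cc(C(=O)O)ccc1CN1CCC[C@H](O[C@H](CO)c2cc(Cl)nc(Cl)c2)[C@@H]1c1ccccc1`, 2400 nM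

Compound 3 carries the lowest number of the three; compound 1 and compound 2 both stand beyond the scatter above it, compound 2 the furthest away. Going by the values given here, no pair of measured compounds differs in only one place, so these pairs show their two values and nothing more.

Compound 4 `Cc1cc(C(=O)O)ccc1CN1CCC[C@H](O[C@H](CO)c2cccc(C(F)(F)F)c2)[C@@H]1c1ccccc1` is not yet measured. It differs from compound 3 in one place: 3-(trifluoromethyl)phenyl in place of 2,6-dichloropyridin-4-yl on a saturated chain carbon bound to an oxygen on a saturated carbon and a saturated chain carbon. Among the compounds with values here, no measured step of this kind exists in the set, so the expectation rests on compound 3 alone. A modest weakening in this assay is expected, the step of a 2.5-fold higher number from compound 3 to compound 4 (0.40 log units; beyond the scatter) being small enough that a result within the scatter would not surprise. Compound 4 is therefore expected to give about 6000 nM in this assay, between 2000 nM and 20000 nM.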

Compound 4, half-maximal effective concentration: 4100 nM
The estimate for compound 4 lay 1.5-fold (0.17 log units) above the measured number; the measured number falls inside the stated range.
By their numbers in this assay, from the lowest: compounds 3 and 4 (each within the scatter of the next); then compounds 1 and 2 (each within the scatter of the next).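

In this assay, 3-(trifluoromethyl)phenyl stands in place of 2,6-dichloropyridin-4-yl on the saturated chain carbon with a small step (a 1.7-fold higher number from compound 3 to compound 4 (0.23 log units; within the scatter)). Going by these compounds alone, this gives the first one-place reading: the two aromatic groups are not told apart at this place, although the pyridine nitrogen and both chlorines leave together. Nothing measured here bears on this result.

The contribution of the pyridine nitrogen and of each chlorine remains unseparated. From the compounds shown here alone, how a nitrile or a methoxy group would read at this place also remains open.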